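The source may report more compounds than this note shows. Statements on the series, on what has been measured and on what is new or still open speak of the compounds shown alone.

Measured so far:
Compound 1 `COc1cccc(-c2csc(NC(=O)c3ccc([N+](=O)[O-])cc3)n2)c1`: > 90000 nM
Compound 2 `O=C(Nc1nc(-c2cccc(C(F)(F)F)c2)cs1)c1ccc([N+](=O)[O-])o1`: 23900 nM

Of the compounds shown here, two from this series have been tested in an ADME assay on Vero cells (Chlorocebus sabaeus) for cytotoxicity, read by MTT assay, with a stated time of 72 h; on this read-out higher numbers stand for weaker inhibition and lower numbers for stronger inhibition. Compound 1 `COc1cccc(-c2csc(NC(=O)c3ccc([N+](=O)[O-])cc3)n2)c1` reaches only a limit there, > 90000 nM, so no number is attached to it. Compound 2 `O=C(Nc1nc(-c2cccc(C(F)(F)F)c2)cs1)c1ccc([N+](=O)[O-])o1` gives 23900 nM in this assay. Among the compounds with values here, compound 2 is therefore the only compound with an actual number in this assay; the other value is the limit described by the limit of > 90000 nM in this assay, at which 1 of the 2 values shown sits.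

Compound 3 `O=C(Nc1cccc(-c2csc(NC(=O)c3ccc([N+](=O)[O-])o3)n2)c1)c1ccccc1` has not yet been measured. It differs from compound 2 in one place: benzamido in place of trifluoromethyl on an aromatic carbon. Within the data shown here, no step between two measured compounds is available, so the size of this change cannot be read from earlier pairs and has to be estimated. The trifluoromethyl of compound 2 gives way to a much larger benzamido group, and the expectation is a moderate step toward weaker inhibition in this assay, roughly a 1.7-fold higher number from compound 2 to compound 3 (0.22 log units; within the scatter). Compound 3 is thus expected to give about 40000 nM in this assay, within a range from 10000 nM to 150000 nM, with a fair chance that only a limit is reported.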

Compound 3, half-maximal inhibitory concentration: 50200 nM
The estimate for compound 3 lay 1.3-fold (0.10 log units) below the measured number, within the range that was stated.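

In this assay, within the data shown here, the first step that can be read is benzamido in place of trifluoromethyl on an aromatic carbon, and it amounts to a 2.1-fold higher number from compound 2 to compound 3 (0.32 log units; beyond the scatter). The entering group is much larger, bringing a second six-membered aromatic ring, a hydrogen-bond donor and a hydrogen-bond acceptor, yet the step is only modest and lies just beyond the usual scatter of repeated measurements. Compound 1 remains a limit and not a number, so no step can be read from it: the limit of > 90000 nM in this assay, at which 1 of the 3 values shown sits.

A single step cannot separate what the added ring contributes from what the amide link contributes, so the compounds shown give no cause for the change. As far as these compounds go, it also remains open whether a small amine, a carboxylic acid or a longer carbon chain on this same aromatic carbon would shift the number in the same direction, or whether the step seen here holds only for benzamido.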